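The source may hold more compounds than are shown below. What is called first, only, known or untested is meant among the compounds shown, and "the series" means these compounds.

Measured compounds:
Compound 1 `Cc1cccc(NC(=O)Nc2ccc(-c3cc(C)nc4noc(N)c34)cc2)c1` — in an ADME assay on HUVEC cells (Homo sapiens) for antiproliferative activity, read by fluorescence, with a stated time of 72 h (on this read-out lower numbers stand for stronger inhibition and higher numbers for weaker inhibition), compound 1 gives 11700 nM
Compound 2 `Cc1cc(-c2ccc(NC(=O)Nc3cccc(C(F)(F)F)c3)cc2)c2c(N)onc2n1` — in this assay compound 2 gives 7950 nM

Among the measured compounds shown here, compound 2 has the lowest of the two numbers, yet its only neighbour, compound 1, sits within the scatter: the step of a 1.5-fold lower number from compound 1 to compound 2 (0.17 log units; within the scatter) is small. Compound 3 `Cc1cc(-c2ccc(NC(=O)Nc3ccc(Cl)c(C(F)(F)F)c3)cc2)c2c(N)onc2n1` differs from compound 2 by chloro in place of hydrogen on an aromatic carbon, placed on an aromatic carbon of a six-membered aromatic ring of carbon only, para to a large group. For the measured compounds named here, no measured step bears directly on this change; the one step available was within the scatter, so no large move is expected. Compound 3 is therefore estimated at 5000 nM, within 1500 nM to 15000 nM. This estimate means a step of a 1.6-fold lower number from compound 2 to compound 3 (0.20 log units; within the scatter) in this assay.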

Compound 3, half-maximal inhibitory concentration: 12600 nM
Compound 3: middle estimate off by 2.5-fold (0.40 log units), on the low side; the measured number falls inside the stated range.
By their numbers in this assay, from the lowest: compounds 2, 1 and 3 (each within the scatter of the next).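

Chloro in place of hydrogen, on the aromatic carbon ortho to a trifluoromethyl group and para to a large group, gives a 1.6-fold higher number from compound 2 to compound 3 (0.20 log units; within the scatter) in this assay. So this position, untouched in the earlier compounds, takes a chloro without a move beyond the scatter. No supporting measurement bears on this result.

The compounds shown leave open whether a different group on this carbon, such as an amine or a carboxylic acid, would move the number beyond the scatter. They also leave open whether chloro would do so without the trifluoromethyl group.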